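The compounds below may be only part of what the source reports. "The series", "measured", "known", "first", "only" and "open" are said of these compounds alone.

Of the compounds shown here, three have been measured in a functional assay on MDA-MB-231 cells (Homo sapiens) for antiproliferative activity, read by sulforhodamine B assay, with a stated time of 48 h; on this read-out lower numbers stand for stronger inhibition of growth and higher numbers for weaker inhibition of growth: compound 1 (`Cc1ccc(-c2nnc(C3=C(Cl)c4ccccc4CCC3)o2)cc1`), compound 2 (`Cc1cc2c(cc1C)C(Cl)=C(c1nnc(-c3ccccc3)o1)CCC2`) and compound 3 (`COc1ccc([N+](=O)[O-])c(-c2nnc(C3=C(Cl)c4cc(C)c(C)cc4CCC3)o2)c1OC`). Compound 2 gives 2760 nM. This number lies within the scatter of compound 1, at 1400 nM, and higher, beyond the scatter, than that of compound 3, at 1160 nM.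

Compound 4 (`Cc1cc2c(cc1C)C(Cl)=C(c1nnc(-c3cccc(Cl)c3)o1)CCC2`) has not yet been measured. It is compound 2 with a single change, phenyl to 3-chlorophenyl: chloro in place of hydrogen on an aromatic carbon. For the measured compounds named here, no two measured compounds differ in one place alone, so the data offer no direct measure of such a change. The measured values span only a narrow range, from compound 3 at 1160 nM to compound 2 at 2760 nM, so a small step in this assay is expected, towards a slightly lower number and probably not beyond the scatter. The expected step is a 1.5-fold lower number from compound 2 to compound 4 (0.16 log units; within the scatter). For compound 4 the estimated value is 1900 nM, with an expected range from 800 nM to 4200 nM.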

Compound 4, concentration for 50% growth inhibition: 3310 nM
Compound 4: the middle estimate sits 1.7-fold (0.24 log units) below what was measured; the measured number falls inside the stated range.
By their numbers in this assay, from the lowest: compounds 3, 1, 2 and 4 (each within the scatter of the next, the first and the last beyond it).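

In this assay, for the compounds shown here, phenyl to 3-chlorophenyl gives a 1.2-fold higher number from compound 2 to compound 4 (0.08 log units; within the scatter), the first step here that isolates a single place: chloro in place of hydrogen on this aromatic carbon, meta to a large group, stays within the scatter. The earlier compounds shown here, no two of which differed in one place alone, could not show that this position takes a chloro without a step beyond the scatter. Nothing given here accounts for this outcome.

From the compounds shown here alone, whether chloro would give so small a step elsewhere on this phenyl remains open, as does whether an amine or a carboxylic acid at this same position would give a step beyond the scatter. Going by these compounds alone, with only one step available, no trend across groups on this ring can be stated.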